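Benzylthio Sulfonylguanidines: Swapping the Benzyl Substituent

The source may report more compounds than this note shows. Statements on the series, on what has been measured and on what is new or still open speak of the compounds shown alone.

Of the compounds shown here, three sharing one core have been tested in a functional assay on HCT-116 cells (Homo sapiens) for cytotoxicity, read by MTT assay, with a stated time of 72 h; on this read-out higher numbers stand for weaker inhibition and lower numbers for stronger inhibition. Compound 1 `Cc1ccc(CSc2cc(Cl)c(C)cc2S(=O)(=O)/N=C(\N)n2nc(C)cc2-c2ccccc2)cc1` gives 28000 nM, compound 2 `Cc1cc(S(=O)(=O)/N=C(\N)n2nccc2-c2ccccc2)c(SCc2ccccc2C)cc1Cl` gives 16000 nM, and compound 3 `Cc1cc(S(=O)(=O)/N=C(\N)n2nccc2-c2ccccc2)c(SCc2cccc(C(F)(F)F)c2)cc1Cl` gives 14000 nM, the lowest of the three numbers, though its gaps to the other two stay within the scatter. Among the measured compounds shown here, the one single-point step, a 1.1-fold lower number from compound 2 to compound 3 (0.06 log units; within the scatter), is likewise within the scatter. Compound 4 `Cc1ccc(CSc2cc(Cl)c(C)cc2S(=O)(=O)/N=C(\N)n2nccc2-c2ccccc2)cc1` differs from compound 3 by 4-methylphenyl in place of 3-(trifluoromethyl)phenyl on a saturated chain carbon bound to a sulfur. Compound 1 already carries a 4-methylphenyl there, and its value and that of compound 3 lie within the scatter of each other. For the measured compounds named here, no step seen so far has moved this assay beyond the scatter, so compound 4 is expected to give 18000 nM (range 9000 nM to 36000 nM), an expected step of a 1.3-fold higher number from compound 3 to compound 4 (0.11 log units; within the scatter).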

Compound 4, half-maximal inhibitory concentration: 14000 nM
Beside the measured number, compound 4's estimate is 1.3-fold (0.11 log units) above it; measured number inside the range.
By their numbers in this assay, from the lowest: compounds 3, 4, 2 and 1 (each within the scatter of the next).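

In this assay the 4-methylphenyl on a saturated chain carbon bound to a sulfur cannot be told apart from the 3-(trifluoromethyl)phenyl, with no change at the digits printed from compound 3 to compound 4 (within the scatter) and likewise from the 2-methylphenyl, with a 1.1-fold lower number from compound 2 to compound 4 (0.06 log units; within the scatter) so this place has now taken three different aryl groups with no change beyond the scatter. Compound 4 also gives a reading for hydrogen in place of methyl on an aromatic carbon, with a 2.0-fold lower number from compound 1 to compound 4 (0.30 log units; within the scatter) and this too stays within the scatter. No measurement offers an explanation for these results. Still open, going by these compounds, is whether an amine or a carboxylic acid on that phenyl ring, or a longer chain in place of the benzyl carbon, would move the number beyond the scatter.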